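A few compounds are considered here, and "the series" means these few. Any claim that something is new, unique, unknown or untested is made for them only; others in the source may bear on it.

Compound 1, `C/C(=C\C(=O)Nc1ccccc1OCCCC(=O)O)c1ccc2c(ccn2Cc2ccc(F)cc2)c1`, gives 97 nM in an assay on Prostate gland for inhibition of steroid 5-alpha-reductase (Rattus norvegicus); a lower number here means a stronger inhibitor, a higher number a weaker inhibitor.
Compound 2, `COc1ccc(Cn2ccc3cc(/C(C)=C/C(=O)Nc4ccccc4OCCCC(=O)O)ccc32)cc1`, gives 480 nM in this assay.

Of these two numbers, compound 2 holds the higher one and is therefore the weaker inhibitor of the pair. Within the data shown here, its only neighbour is compound 1, and the single step in hand, a 4.9-fold higher number from compound 1 to compound 2 (0.69 log units; beyond the scatter), puts a methoxy in place of a fluoro on an aromatic carbon, with the methoxy on the side of the higher number.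

Compound 3, `C/C(=C\C(=O)Nc1ccccc1OCCCC(=O)O)c1ccc2c(ccn2C(C)c2ccccc2)c1`, is not yet measured. It differs from compound 2 by 1-phenylethyl in place of 4-methoxybenzyl on an aromatic nitrogen. The group that leaves is the one carrying the methoxy that went with the weaker value in the step between compound 1 and compound 2; the group that enters, 1-phenylethyl, carries no methoxy. Among the measured compounds shown here, that step is the only guide, and it points toward a lower number once the methoxy is gone, although nothing in hand speaks to the rest of the change. The expected step is a modest drop, a 2.4-fold lower number from compound 2 to compound 3 (0.38 log units; beyond the scatter). Compound 3 is therefore estimated at 200 nM, within a range from 60 nM to 700 nM.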

Compound 3, half-maximal inhibitory concentration: 19 nM
Estimate against measurement, compound 3: 11-fold (1.02 log units) above; measured number outside the range, below it.
By their numbers in this assay, from the lowest: compound 3; then compound 1; then compound 2.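

On the aromatic nitrogen, 1-phenylethyl gives a stronger inhibitor in this assay than either benzyl group shown so far: the swap from 4-methoxybenzyl is a 25-fold lower number from compound 2 to compound 3 (1.40 log units; beyond the scatter) and the swap from 4-fluorobenzyl is a 5.1-fold lower number from compound 1 to compound 3 (0.71 log units; beyond the scatter) in size. Before this result, the only information about this position was the exchange of one ring substituent for another, a 4.9-fold higher number from compound 1 to compound 2 (0.69 log units; beyond the scatter), so the new steps show that a change in the group on this nitrogen can move the number further than that exchange did, and that the best of the three groups carries no substituent on its ring at all. No measurement is available that explains why this group does better.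

Each new step changes two things at once, removing the ring substituent and adding a methyl group to the carbon that carries the ring, so the compounds shown cannot say how much each contributes. On these data alone, a plain benzyl group, a 1-(4-fluorophenyl)ethyl group and a longer chain such as 1-phenylpropyl would each help to separate these contributions, and the single mirror-image forms of 1-phenylethyl also remain open.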